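Chloro for methoxy on the pendant aryl of the fused lactam

The source may report more compounds than this note shows. Statements on the series, on what has been measured and on what is new or still open speak of the compounds shown alone.

Two members of this series have numbers. In a functional assay on A549 cells (Homo sapiens) for inhibition, read by MTT assay, with a stated time of 48 h (on this read-out higher numbers stand for weaker inhibition and lower numbers for stronger inhibition), compound 1 `CC(C)N1CCn2nc(-c3ccc(Cl)cc3)cc2C1=O` gives 31000 nM. Compound 2 `COc1ccc(-c2cc3n(n2)CCN(Cc2ccc(Cl)nc2)C3=O)cc1` stands apart: in this assay compound 2 gives only the limit > 64000 nM, not a number. Among the measured compounds shown here, this is the limit of > 64000 nM in this assay, at which 1 of the 2 values shown sits, so no measured step between the two compounds can be stated; their values show only that compound 1 sits inside the measured range and compound 2 does not.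

Compound 3 `O=C1c2cc(-c3ccc(Cl)cc3)nn2CCN1Cc1ccc(Cl)nc1` differs from compound 2 by chloro in place of methoxy on an aromatic carbon, the whole group reading 4-methoxyphenyl to 4-chlorophenyl. Compound 1 carries the same 4-chlorophenyl and gives 31000 nM in this assay, which argues for a weak but measurable value. The step of an at least 1.6-fold lower number from compound 2 to compound 3 (0.20 log units; that floor lies within the scatter) is therefore expected to be small, toward stronger inhibition, and close to the scatter. Compound 3 is estimated at 40000 nM, between 15000 nM and 120000 nM, with a fair chance that only a limit is reported.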

Compound 3, half-maximal inhibitory concentration: 39500 nM
Beside the measured number, compound 3's estimate is 1.0-fold (0.01 log units) above it, and the stated range covers the measured number.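

In this assay, the change from 4-methoxyphenyl to 4-chlorophenyl gives a measured number where there was only a limit, a step of an at least 1.6-fold lower number from compound 2 to compound 3 (0.20 log units; that floor lies within the scatter). That step is only a floor, because compound 2 stands at a limit and not at a number: the limit of > 64000 nM in this assay, at which 1 of the 3 values shown sits. With the 4-chlorophenyl held fixed, replacing isopropyl with (6-chloropyridin-3-yl)methyl on the amide-type nitrogen gives a 1.3-fold higher number from compound 1 to compound 3 (0.11 log units; within the scatter), so the two groups are not told apart at this nitrogen.

As far as these compounds go, whether a nitrile or an amine on this aromatic carbon, para to a large group, would give a step beyond the scatter remains open. So does whether a longer chain or a carboxylic acid on the amide-type nitrogen would separate from isopropyl.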